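The source may report more compounds than this note shows. Statements on the series, on what has been measured and on what is new or still open speak of the compounds shown alone.

Compound 3 `CCCCn1cc(C(=O)NCc2ccccc2)c(=O)c2cc(F)c(N3CCC(C(N)=O)CC3)cc21` is the only one of the three measured compounds to return an actual number in an ADME assay on J774.1 cells (Mus musculus) for cytotoxicity, read by resazurin assay, with a stated time of 48 h; a higher number here means a weaker inhibitor, a lower number a stronger inhibitor: compound 3 gives 47000 nM. Compound 1 `CCCCn1cc(C(=O)NCc2ccc(OC)c([N+](=O)[O-])c2)c(=O)c2cc(F)c(N3CCC(C(N)=O)CC3)cc21` reaches only a limit of the assay, and in this assay compound 1 gives > 100000 nM. Compound 2 `CCCCn1cc(C(=O)NCc2ccc([N+](=O)[O-])cc2)c(=O)c2cc(F)c(N3CCC(C(N)=O)CC3)cc21` likewise reaches a limit, and in this assay compound 2 gives > 100000 nM. Within the data shown here, compound 3 thus stands alone as the single compound with a readable value, while the two other values sit at the limit of > 100000 nM in this assay, at which 2 of the 3 values shown sit.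

Compound 4 `CCCCn1cc(C(=O)NCc2ccc(O)cc2)c(=O)c2cc(F)c(N3CCC(C(N)=O)CC3)cc21` differs from compound 3 by hydroxy in place of hydrogen on an aromatic carbon. Among the measured compounds shown here, two measured steps bear on a change at this ring. The step of an at least 2.1-fold lower number from compound 1 to compound 3 (0.32 log units; beyond the scatter) and the step of an at least 2.1-fold lower number from compound 2 to compound 3 (0.32 log units; beyond the scatter) both show that taking a group off the ring gave a lower number, whereas the step that the two limits leave unreadable from compound 1 to compound 2 cannot be read. Putting a hydroxy group onto the ring is therefore expected to move the number the other way, toward a higher value, although hydroxy is neither nitro nor methoxy and the size of the move is uncertain. Compound 4 is expected to give 80000 nM in this assay, within a range from 35000 nM to 200000 nM, which means an expected step of a 1.7-fold higher number from compound 3 to compound 4 (0.23 log units; within the scatter).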

Compound 4, half-maximal inhibitory concentration: 41600 nM
Compound 4: the middle estimate sits 1.9-fold (0.28 log units) above what was measured; measured number inside the range.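

The step at this position in this assay reads a 1.1-fold lower number from compound 3 to compound 4 (0.05 log units; within the scatter), so a hydroxy group on the aromatic carbon para to a large group gives a number that cannot be told apart from that of the unsubstituted ring. Among these compounds, the earlier compounds showed only that rings bearing nitro sat higher than the bare phenyl ring, and compound 4 now shows that a group at this place does not by itself bring such a result: hydroxy in place of nitro gives an at least 2.4-fold lower number from compound 2 to compound 4 (0.38 log units; beyond the scatter), and the wider change from the 4-methoxy-3-nitrophenyl ring gives an at least 2.4-fold lower number from compound 1 to compound 4 (0.38 log units; beyond the scatter). These two steps give minimum sizes rather than full ones, and the step from compound 1 to compound 2 cannot be read: the limit of > 100000 nM in this assay, at which 2 of the 4 values shown sit.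

The compounds shown leave open whether an amine or a carboxylic acid at this same ring carbon would group with hydroxy or with nitro, and whether a methoxy group alone, without a nitro group on the ring, would give a readable number. They also leave open how the number would respond to a longer chain in place of the butyl group on the shared core.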